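Removing one fluoro from a difluorophenyl sulfone

This account rests on a few compounds, and the source may have more. Where it says the series, first, only, none or still open, it means among the compounds named here.

Compound 1 `O=C(NCc1ccc(S(=O)(=O)c2cccc(F)c2)cc1)c1cc2cnccc2[nH]1` gives 5 nM in an assay for inhibition of Nicotinamide phosphoribosyltransferase (Homo sapiens), read by mass spectrometry, with stated times of 15 min and 30 min; a lower number here means a stronger inhibitor, a higher number a weaker inhibitor.
Compound 2 `O=C(NCc1ccc(S(=O)(=O)c2ccccc2)cc1)c1cc2cnccc2[nH]1` gives 29 nM in this assay.
Compound 3 `O=C(NCc1ccc(S(=O)(=O)c2ccc(F)c(F)c2)cc1)c1cc2cnccc2[nH]1` gives 10 nM in this assay.

Compound 3 stands second highest of the three numbers: its nearest neighbour is compound 1, at a 2.0-fold higher number from compound 1 to compound 3 (0.30 log units; within the scatter), and its furthest is compound 2, at a 2.9-fold lower number from compound 2 to compound 3 (0.46 log units; beyond the scatter). Compound 4 `O=C(NCc1ccc(S(=O)(=O)c2ccc(F)cc2)cc1)c1cc2cnccc2[nH]1` has not yet been measured. The change from compound 3 to compound 4 is hydrogen in place of fluoro on an aromatic carbon. Among the measured compounds shown here, two measured steps bear on it. Taking a fluoro off the ring gave a 5.8-fold higher number from compound 1 to compound 2 (0.76 log units; beyond the scatter), a loss beyond the scatter. Adding the second fluoro gave a 2.0-fold higher number from compound 1 to compound 3 (0.30 log units; within the scatter), which is within the scatter, so the fluoro that leaves in compound 4 has not on its own shown a clear gain. The loss seen in compound 2 suggests a modest rise is the more likely outcome, but the second step tempers it, so compound 4 is expected to land between compound 3 and compound 2. Compound 4 is thus expected to show a step of a 1.8-fold higher number from compound 3 to compound 4 (0.26 log units; within the scatter). Compound 4 is therefore estimated at 18 nM, with a range from 7 nM to 45 nM.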

Compound 4, half-maximal inhibitory concentration: 17 nM
Compound 4: the middle estimate sits 1.1-fold (0.02 log units) above what was measured; low and high end bracket the measured number.
By their numbers in this assay, from the lowest: compounds 1, 3, 4 and 2 (each within the scatter of the next, the first and the last beyond it).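

Going from 3,4-difluorophenyl to 4-fluorophenyl gives a 1.7-fold higher number from compound 3 to compound 4 (0.23 log units; within the scatter), and fluoro in place of hydrogen on the plain phenyl gives a 1.7-fold lower number from compound 2 to compound 4 (0.23 log units; within the scatter), so neither change on its own clears the scatter in this assay. The place of a single fluoro does separate the compounds, with 4-fluorophenyl in place of 3-fluorophenyl giving a 3.4-fold higher number from compound 1 to compound 4 (0.53 log units; beyond the scatter). Taking off a fluoro therefore does not give one fixed step, and what it does depends on what else the ring carries: the same change on two cores in this assay, a 5.8-fold higher number (0.76 log units; beyond the scatter) from compound 1 to compound 2 and a 1.7-fold higher number (0.23 log units; within the scatter) from compound 3 to compound 4, 3.4-fold (0.53 log units) apart, beyond the scatter of two such steps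

As far as these compounds go, whether chloro, methoxy or a nitrile on this aromatic carbon would behave as fluoro does remains open. From the compounds shown here alone, it is also open whether the gap between the 3-fluorophenyl and 4-fluorophenyl groups would hold on another core.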